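This account rests on a few compounds, and the source may have more. Where it says the series, first, only, none or still open, it means among the compounds named here.

Working notes on the series.

Compound 1 `COc1cc2nc(N3CCC[C@@H](N)C3)nc(N)c2cc1OC` is the weaker of the two measured entries. Going by the values given here, in an assay on CHO cells for displacement of a labelled ligand from Alpha-1D adrenergic receptor (Homo sapiens), with a stated time of 30 min (on this read-out higher numbers stand for weaker inhibition and lower numbers for stronger inhibition), compound 1 gives 102 nM, the highest of the two numbers measured so far. Its enantiomer compound 2 `COc1cc2nc(N3CCC[C@H](N)C3)nc(N)c2cc1OC` gives 28.2 nM in this assay, and the step of a 3.6-fold lower number from compound 1 to compound 2 (0.56 log units; beyond the scatter) is attributable to the fact that compounds 1 and 2 differ only in the configuration as drawn alone, as the two compounds are otherwise identical.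

Compound 3 `COc1cc2nc(N3CCC[C@@H](NC(=O)c4ccco4)C3)nc(N)c2cc1OC` is built from compound 1 by the change ((furan-2-yl)carbonyl in place of hydrogen on an amine nitrogen), so the stereocentre of compound 1 is retained and only the amine substituent changes. Among the compounds with values here, the one measured step in this assay, the inversion of configuration from compound 1 to compound 2, does not address substitution on the amine nitrogen, so no measured step bears on the change to compound 3. The direction of the step in this assay is therefore open on the data in hand, and the estimate carries a wide range. Compound 3 is expected to give about 30 nM in this assay, between 5 nM and 150 nM, that is a step of a 3.4-fold lower number from compound 1 to compound 3 (0.53 log units; beyond the scatter) estimated from compound 1.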

Compound 3, inhibition constant: 37.2 nM
Estimate against measurement, compound 3: 1.2-fold (0.09 log units) below; the range from low to high includes it.
By their numbers in this assay, from the lowest: compounds 2 and 3 (each within the scatter of the next); then compound 1.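

On the amine nitrogen of the core of compound 1, putting (furan-2-yl)carbonyl in place of hydrogen gives in this assay a step of a 2.7-fold lower number from compound 1 to compound 3 (0.44 log units; beyond the scatter) and thus stronger inhibition, not weaker. Going by these compounds alone, the earlier pair varied only the configuration at the saturated ring carbon, so this is the first reading on the nitrogen itself: with the configuration of compound 1 retained, the free amino group can give way to ((furan-2-yl)carbonyl)amino without loss on this read-out. None of the evidence in hand bears on why this change on the nitrogen moves the number in this direction.

The compounds shown leave open whether the same (furan-2-yl)carbonyl group gives a step of like size and direction on the configuration of compound 2, since that pair of compounds has no reading here. They also leave open whether the step belongs to the furan ring or to the carbonyl, which a simple acetyl group, a benzoyl group or a thiophene-2-carbonyl group on the same nitrogen would separate.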